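This account rests on a few compounds, and the source may have more. Where it says the series, first, only, none or still open, it means among the compounds named here.

Compounds measured so far:

compound 1 `Cn1ncnc1-c1ccccc1NCC1=NCCN1` — 63.1 nM
compound 2 `CCn1ncnc1-c1ccccc1NCC1=NCCN1` — 126 nM
compound 3 `Cn1cc(-c2ccccc2NCC2=NCCN2)cn1` — < 100000 nM

The three compounds were tested in an in vitro functional assay on cells (Fibroblast) for agonist activity at Alpha-1D adrenergic receptor (Homo sapiens); on this read-out lower numbers stand for an effect already at smaller amounts and higher numbers for an effect only at larger amounts of compound. Compound 1 `Cn1ncnc1-c1ccccc1NCC1=NCCN1` gives 63.1 nM in this assay, and compound 2 `CCn1ncnc1-c1ccccc1NCC1=NCCN1` gives 126 nM. The two differ by one change, (methyl in place of hydrogen on a saturated chain carbon bound to an aromatic nitrogen), and the step is a 2.0-fold higher number from compound 1 to compound 2 (0.30 log units; within the scatter).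

Compound 3 `Cn1cc(-c2ccccc2NCC2=NCCN2)cn1` carries a different core, (1-methyl-1H-pyrazol-4-yl in place of 1-methyl-1H-1,2,4-triazol-5-yl on an aromatic carbon). For compound 3 this assay reports only a limit, < 100000 nM, and at that limit (the limit of < 100000 nM in this assay, at which 1 of the 3 values shown sits). The step that the limit leaves unreadable from compound 1 to compound 3 therefore cannot be sized.

Compound 4 `CCn1cc(-c2ccccc2NCC2=NCCN2)cn1` has not yet been measured in this assay. It differs from compound 3 by methyl in place of hydrogen on a saturated chain carbon bound to an aromatic nitrogen, the same change that separates compound 1 from compound 2. That earlier step, a 2.0-fold higher number from compound 1 to compound 2 (0.30 log units; within the scatter), lay within the scatter of the assay, so no real shift in activity was seen from adding the methyl on the saturated chain carbon bound to the aromatic nitrogen.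

On that basis compound 4 is expected to behave much like compound 3, with an estimated step of a number no lower from compound 3 to compound 4 (the limit leaves the size open), because the same change gave only a 2.0-fold higher number from compound 1 to compound 2 (0.30 log units; within the scatter). Since compound 3 itself reached only a limit, compound 4 is likely to return a limit as well rather than a number. The estimate for compound 4 is 100000 nM, with a range from 30000 nM to 100000 nM.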

Compound 4, half-maximal effective concentration: < 100000 nM
Compound 4 gave a limit, no number; the forecaster's own chance of this, stated with the estimate: 80%; the middle value lies on the limit itself.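

Compound 3 and compound 4 both stand only at a limit in this assay, so no step between them can be read: the limit of < 100000 nM in this assay, at which 2 of the 4 values shown sit.

The compounds shown leave open whether methyl in place of hydrogen on a saturated chain carbon bound to an aromatic nitrogen changes the read-out at all in this pair, and how far compound 3 and compound 4 lie from compound 1 and compound 2.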